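Cytotoxicity notes on a pair of ether analogues

The compounds below may be only part of what the source reports. "The series", "measured", "known", "first", "only" and "open" are said of these compounds alone.

Measured so far:
- compound 1 `CCC1(Cc2ccccc2)OS(=O)(=O)C=C1OCC#N`: > 400000 nM
- compound 2 `CCC1(Cc2ccccc2)OS(=O)(=O)C=C1OCCCCCCc1ccccc1`: >= 20000 nM

In an ADME assay on HEL cells (Homo sapiens) for cytotoxicity, with a stated time of 3 days (on this read-out higher numbers stand for lower toxicity in this test and lower numbers for higher toxicity in this test), neither value is a number; both are limits of the test. For compound 1 the figure > 400000 nM is a limit (the limit of > 400000 nM in this assay, at which 1 of the 2 values shown sits). For compound 2 the figure >= 20000 nM is likewise a limit (the limit of >= 20000 nM in this assay, at which 1 of the 2 values shown sits). Within the data shown here, no step can be computed between two limits, so compound 1 stands only at the upper boundary of what this assay reports, with no measured cytotoxicity within range.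

Compound 3 `C=CCOC1=CS(=O)(=O)OC1(CC)Cc1ccccc1` differs from compound 1 as follows: vinyl in place of cyano on a saturated chain carbon bound to an oxygen on an unsaturated carbon. Among the measured compounds shown here, nothing among the measured compounds points to a shift in this assay beyond the scatter for this swap of cyanomethoxy to allyloxy. Compound 3 is therefore expected to give about 300000 nM in this assay, within 60000 nM to 400000 nM. The expected step of an at least 1.3-fold lower number from compound 1 to compound 3 (0.12 log units; that floor lies within the scatter) is estimated as none beyond the scatter, with a limit again the likely outcome.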

Compound 3, minimum cytotoxic concentration: 80000 nM
Compound 3: middle estimate off by 3.8-fold (0.57 log units), on the high side; low and high end bracket the measured number.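

In this assay, among these compounds, vinyl in place of cyano on a saturated chain carbon bound to an oxygen on an unsaturated carbon is the first change in this place with a readable size: an at least 5.0-fold lower number from compound 1 to compound 3 (0.69 log units; beyond the scatter). Compound 3 gives 80000 nM, a measured number rather than a limit, so a cytotoxic concentration is now seen within the range of the test for an ether of this series. Compound 1 remains a limit, so the step has only a floor and no upper size: the limit of > 400000 nM in this assay, at which 1 of the 3 values shown sits.

The compounds shown do not tell whether the lower number follows the loss of the nitrile or the arrival of the vinyl group. An ethyl group or a primary amine in the same place would help to separate the two.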